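The compounds below may be only part of what the source reports. "The series", "measured", "known", "first", "only" and "open" are said of these compounds alone.

Working notes on the series. In a functional assay on HCT-15 cells (Homo sapiens) (a higher number here means that more compound is needed for the effect, a lower number that less compound is needed), compound 1 (`COc1cc(C2OC(c3ccc(N(C)C)cc3)=NN2C=O)cc(OC)c1OC`) gives 0.096 uM, compound 2 (`COC(=O)N1N=C(c2ccc(N(C)C)cc2)OC1c1cc(OC)c(OC)c(OC)c1`) gives 40 uM, and compound 3 (`COc1cc(C2OC(c3ccc(N(C)C)cc3)=NN2C(=O)CN=[N+]=[N-])cc(OC)c1OC`) gives 0.15 uM. Two steps place the azidomethyl member of the series: a 1.6-fold higher number from compound 1 to compound 3 (0.19 log units; within the scatter), and a 270-fold lower number from compound 2 to compound 3 (2.43 log units; beyond the scatter). It therefore sits in the low-number group and far from the methoxy member.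

The next member is compound 4 (`COc1cc(C2OC(c3ccc(N(C)C)cc3)=NN2C(=O)CNC=O)cc(OC)c1OC`), which has formylamino in place of azido on a saturated chain carbon bound to a carbonyl carbon.

Going by the values given here, no measured step covers this exact exchange, so the evidence is indirect. Azidomethyl on the carbonyl carbon leaves the number within the scatter, as a 1.6-fold higher number from compound 1 to compound 3 (0.19 log units; within the scatter) shows, while methoxy there gives a 420-fold higher number from compound 1 to compound 2 (2.62 log units; beyond the scatter). The group on this carbonyl carbon can thus be changed with no visible cost or with a very large one, and the data do not show which applies here. The retained chain carbon favours the smaller outcome, so a modest step towards a higher number is expected in this assay, well short of the methoxy step.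

The estimated change is a 2.7-fold higher number from compound 3 to compound 4 (0.43 log units; beyond the scatter). For compound 4 the estimated value is 0.4 uM, with an expected range of 0.1 uM to 2 uM.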

Compound 4, concentration for half-maximal effect: 0.035 uM
Compound 4: the middle estimate sits 11-fold (1.06 log units) above what was measured; the measured number lies below the stated range.
By their numbers in this assay, from the lowest: compound 4; then compounds 1 and 3 (each within the scatter of the next); then compound 2.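

In this assay the exchange of azido for formylamino on a saturated chain carbon bound to a carbonyl carbon gives a 4.3-fold lower number from compound 3 to compound 4 (0.63 log units; beyond the scatter), so the group carried on this chain carbon can move the number beyond the scatter, which the azidomethyl member alone could not show. The (formylamino)methyl group in place of hydrogen on a carbonyl carbon gives a 2.7-fold lower number from compound 1 to compound 4 (0.44 log units; beyond the scatter), the only step shown that lowers the number from compound 1, and in place of methoxy it gives a 1100-fold lower number from compound 2 to compound 4 (3.06 log units; beyond the scatter), so this position allows changes in both directions. No measurement on these groups bears on why the number falls.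

The compounds shown leave open whether the step depends on the carbonyl of the formylamino group or on the amide hydrogen, a question that an acetylamino group, a plain amine or a dimethylamino group on the same chain carbon would address. They also leave open whether a longer chain carrying the formylamino group keeps the number this low.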